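Removing the phenyl from a cathepsin S nitrile inhibitor

This account rests on a few compounds, and the source may have more. Where it says the series, first, only, none or still open, it means among the compounds named here.

Measured compounds:
- compound 1 `N#C[C@@]1(NC(=O)[C@@H](CC(=O)N2CCOCC2)CC2CCC(c3ccccc3)CC2)CCN(C2CCCCC2)C1`: 3140 nM
- compound 2 `N#C[C@H](CCc1ccccc1)NC(=O)[C@@H](CC(=O)N1CCOCC1)CC1CCCCC1`: 171 nM
- compound 3 `CN1CCC(C#N)(NC(=O)[C@@H](CC(=O)N2CCOCC2)CC2CCCCC2)CC1`: 251 nM

These three compounds were tested in an assay on isolated protein for inhibition of cathepsin S (Homo sapiens); a lower number here means a stronger inhibitor, a higher number a weaker inhibitor. Compound 1 gives the highest of the three numbers, and so is the weakest inhibitor of the set: compound 3 comes nearest, with a number that is lower by a margin beyond the usual scatter, and compound 2 lies furthest, lower still. Compound 2 and compound 3 differ from each other in the part that carries the nitrile, yet both carry the same cyclohexyl side chain that compound 4 will have.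

The step considered here leads from compound 1 to compound 4 `N#C[C@@]1(NC(=O)[C@@H](CC(=O)N2CCOCC2)CC2CCCCC2)CCN(C2CCCCC2)C1`. The change is hydrogen in place of phenyl on a saturated ring carbon, so that a 4-phenylcyclohexyl group becomes a plain cyclohexyl group while everything else stays as it is in compound 1. Going by the values given here, no measured pair shows this exact change on its own, so its size must be guessed from the surrounding numbers. Because compound 2 gives 171 nM and compound 3 gives 251 nM with the cyclohexyl side chain, compound 4 is expected to sit well below compound 1, with an estimated step of a 7.9-fold lower number from compound 1 to compound 4 (0.89 log units; beyond the scatter) in this assay. The estimate for compound 4 is 400 nM, within a range from 120 nM to 1300 nM.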

Compound 4, half-maximal inhibitory concentration: 23 nM
Compound 4: middle estimate off by 17-fold (1.24 log units), on the high side; the whole stated range lies above it.
By their numbers in this assay, from the lowest: compound 4; then compounds 2 and 3 (each within the scatter of the next); then compound 1.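

In this assay, going by these compounds alone, exchanging the phenyl for hydrogen gives a 140-fold lower number from compound 1 to compound 4 (2.14 log units; beyond the scatter), a large step and the first direct reading of this change, as no earlier pair differed in this one place alone. The rest of the molecule is the same in both compounds, so the whole step belongs to this single exchange on a saturated ring carbon, and the plain cyclohexyl group gives by far the stronger inhibitor of the two. This position is therefore highly sensitive to what it carries, but nothing measured here explains why removing the phenyl has so large an effect.

From the compounds shown here alone, only phenyl and hydrogen can be compared at this position, so it remains open where a methyl group, a hydroxyl group or a fluorine atom would fall, and whether a phenyl held on a longer chain would behave like the directly attached one. Going by these compounds, it is also open whether a step of this size would carry over to the different nitrile-bearing parts of compound 2 and compound 3.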